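Chloro for hydrogen on an aromatic carbon: cytotoxicity notes

The compounds below may be only part of what the source reports. "The series", "measured", "known", "first", "only" and "open" are said of these compounds alone.

Compounds in the series:
- compound 1 `CC(C)=CCC[C@@](C)(/C=C/c1ccccc1)/C=C/c1ccc(O)cc1`
- compound 2 `CC(C)=CCC[C@](C)(/C=C/c1ccc(O)cc1)/C=C/c1cccc(Cl)c1`
- compound 3 `C=C[C@@](C)(/C=C/c1ccc(Nc2ccc(Cl)cc2)cc1)CCC=C(C)C`
- compound 4 `C=C[C@@](C)(/C=C/c1ccc(Nc2ccc(Cl)c(Cl)c2)cc1)CCC=C(C)C`, not yet measured

In a functional assay on SEM cells (Homo sapiens) for cytotoxicity, with a stated time of 72 h (a lower number here means that less compound is needed, a higher number that more compound is needed for the effect), compound 1 gives only a limit of the assay, not a number: > 36600 nM. Compound 2 likewise gives a limit, > 36600 nM. Compound 3 also gives a limit, > 36600 nM. Compound 2 differs from compound 1 by chloro in place of hydrogen on an aromatic carbon; the step that the two limits leave unreadable from compound 1 to compound 2 cannot be sized because of the limit of > 36600 nM in this assay, at which 3 of the 3 values shown sit. The difference between the cores of compound 1 and compound 3 is not broken down here.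

Compound 4 differs from compound 3 by chloro in place of hydrogen on an aromatic carbon. The entering group here sits ortho to a chloro group, which the change from compound 1 to compound 2 does not show, so this is the same kind of change, not the same. The step that the limit leaves unreadable from compound 3 to compound 4 is expected to be small or unreadable. That rests on compound 3, whose > 36600 nM is a limit, and on the unreadable step that the two limits leave unreadable from compound 1 to compound 2. Compound 4 is therefore expected to give about 50000 nM, most likely again only a limit.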

Compound 4, half-maximal effective concentration: > 36600 nM
Compound 4: a limit, no number; the forecaster's own chance of this, stated with the estimate: 80%; the middle value is on the limit's open side.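

Compound 4 gives > 36600 nM in this assay, which is a limit and not a number, so no size can be read for the change from compound 3 to compound 4: the limit of > 36600 nM in this assay, at which 4 of the 4 values shown sit.

The compounds shown leave open whether chloro in place of hydrogen on an aromatic carbon alters the half-maximal effective concentration in this assay at all.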